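From Cyclohexyl to Nitro in a Three-Compound Series

The source may report more compounds than this note shows. Statements on the series, on what has been measured and on what is new or still open speak of the compounds shown alone.

compound 1 `CCCCOc1ccccc1C(=O)/C=C/c1cc(OC)cc(OC)c1` – 13000 nM
compound 2 `COc1cc(/C=C/C(=O)c2cccc(F)c2)cc(OC)c1` – 9200 nM
compound 3 `COc1cc(/C=C/C(=O)c2ccc(C3CCCCC3)cc2)cc(OC)c1` – 39000 nM

All three compounds were measured in a functional assay (Homo sapiens) for inhibition; on this read-out higher numbers stand for weaker inhibition and lower numbers for stronger inhibition. Compound 3 stands at the top of these numbers with 39000 nM, making it the weakest inhibitor of the three, and its gaps to compound 1 and compound 2 both lie beyond the scatter. Compound 1 at 13000 nM and compound 2 at 9200 nM lie within the scatter of each other.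

The next compound is compound 4 `COc1cc(/C=C/C(=O)c2ccc([N+](=O)[O-])cc2)cc(OC)c1`, which keeps the shared core of compound 3 and changes one group: nitro in place of cyclohexyl on an aromatic carbon, para to a large group (nitro in place of cyclohexyl on an aromatic carbon). For the measured compounds named here, no measured pair in this small set differs in only one place, so the expectation rests on the three values alone. Of these compounds, only compound 3 carries the cyclohexyl group. Without it, compound 1 gives 13000 nM and compound 2 gives 9200 nM, so compound 4 is expected to fall near them. The expected step of a 3.3-fold lower number from compound 3 to compound 4 (0.51 log units; beyond the scatter) goes towards stronger inhibition and is moderate in size, probably just beyond the scatter. For compound 4 the estimated value is 12000 nM, with an expected range from 4000 nM to 35000 nM.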

Compound 4, half-maximal inhibitory concentration: 20000 nM
Compound 4: middle estimate off by 1.7-fold (0.22 log units), on the low side; low and high end bracket the measured number.
By their numbers in this assay, from the lowest: compounds 2, 1, 4 and 3 (each within the scatter of the next, the first and the last beyond it).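

The exchange of cyclohexyl for nitro on an aromatic carbon, para to a large group, is the first change among these compounds confined to one place, and in this assay it gives a 2.0-fold lower number from compound 3 to compound 4 (0.29 log units; within the scatter), so this read-out does not separate the two compounds. The swap removes a six-membered non-aromatic ring of carbon only and brings in a group with no ring and with hydrogen-bond acceptors, yet the number stays within the usual scatter, which means this one step gives no sign that the choice between these two groups matters at this position. Nothing measured here offers a reason for this outcome.

As far as these compounds go, whether an amine or a carboxylic acid on the same aromatic carbon would give a step beyond the scatter remains open, as does the outcome for a longer chain there. Also open, from the compounds shown here alone, is whether the exchange of cyclohexyl for nitro would give a similar step on the cores of compound 1 or compound 2, which carry other groups in other places.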